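The compounds below may be only part of what the source reports. "The series", "measured", "known", "first", "only" and "open" are said of these compounds alone.

Measured so far in a functional assay (strain AB) with Danio rerio as the target, read by microscopy, with a stated time of 1 h; on this read-out lower numbers stand for an effect already at smaller amounts and higher numbers for an effect only at larger amounts of compound:
compound 1 `CC(C)(C)OC(=O)CCCN1CCc2c(sc(NC(=O)Nc3ccc(Cl)cc3)c2C(N)=O)C1` gives 560 nM.
compound 2 `CC(C)(C)OC(=O)CN1CCc2c(sc(NC(=O)Nc3ccc(Cl)cc3)c2C(N)=O)C1` gives only a limit of the assay, > 25000 nM.

Going by the values given here, compound 1 holds the only actual number in this assay; the one other value is a limit. Among the compounds with values here, the single measured step, an at least 44-fold higher number from compound 1 to compound 2 (1.64 log units; beyond the scatter), concerns the length of the chain on the ring nitrogen, and its size as reported is set by the limit of > 25000 nM in this assay, at which 1 of the 2 values shown sits. Compound 3 `NC(=O)c1c(NC(=O)Nc2ccc(Cl)cc2)sc2c1CCN(CCCNC(=O)CCc1cccnc1)C2` keeps the chain length of compound 1 and alters only its end: ((2-(pyridin-3-yl)ethyl)carbonyl)amino in place of tert-butoxycarbonyl on a saturated chain carbon, three bonds along the chain from an amine nitrogen in a ring. Within the data shown here, no measured step touches the end group, so the step from compound 1 to compound 2 bears on compound 3 only in that the chain length is retained, and a loss of that kind is not expected. The expected step in this assay is a 1.3-fold higher number from compound 1 to compound 3 (0.10 log units; within the scatter), within or close to the scatter. Compound 3 is estimated at 700 nM, with a range from 200 nM to 3000 nM.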

Compound 3, half-maximal effective concentration: 470 nM
For compound 3 the middle estimate is 1.5-fold (0.17 log units) above the measured one, within the range that was stated.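

Swapping the end group on a saturated chain carbon, three bonds along the chain from an amine nitrogen in a ring, gives a 1.2-fold lower number from compound 1 to compound 3 (0.08 log units; within the scatter) in this assay and is the first comparison shown at this end of the chain. The tert-butoxycarbonyl group is therefore not needed for a value of this order, since ((2-(pyridin-3-yl)ethyl)carbonyl)amino, which is larger and brings a six-membered aromatic ring and a hydrogen-bond donor, serves equally well here. No measurement shown offers an explanation for this tolerance.

From the compounds shown here alone, it remains open whether a plain amine or a carboxylic acid at the chain end would fit as well. The compounds shown also leave open whether the pyridine ring matters, which a phenyl ring in its place would test, and how a longer chain would read.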